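The compounds below may be only part of what the source reports. "The series", "measured", "known", "first", "only" and "open" are said of these compounds alone.

Compound 1 `O=C(N[C@H]1CCC[C@H](CO)C1)C1CCN(c2nc3cc(C(F)(F)F)ccc3o2)CC1`: 22.2 mL/min/kg
Compound 2 `Cc1cc2oc(N3CCC(C(=O)N[C@H]4CCC[C@H](CO)C4)CC3)nc2cc1Cl`: 28.3 mL/min/kg
Compound 3 `O=C(N[C@H]1CCC[C@H](CO)C1)C1CCN(c2nc3cc(Br)ccc3o2)CC1`: 25.6 mL/min/kg

In an ADME assay on microsomes from liver (Homo sapiens) for metabolic stability (a lower number here means slower removal, a higher number faster removal of the compound), compound 2 gives 28.3 mL/min/kg, within the scatter of both compound 1 and compound 3. Compound 4 `O=C(N[C@H]1CCC[C@H](CO)C1)C1CCN(c2nc3cc(Cl)c(-c4ccc(OC(F)(F)F)cc4)cc3o2)CC1` departs from compound 2 at one place, ortho to a chloro group: 4-(trifluoromethoxy)phenyl in place of methyl on an aromatic carbon. Among the compounds with values here, the only measured step is a 1.2-fold higher number from compound 1 to compound 3 (0.06 log units; within the scatter), which lies within the scatter. Within the data shown here, it exchanges one small substituent for another, and no measured step adds a ring, so it is a weak guide here. No direction can be drawn from it. In this assay the expected change is a 1.0-fold lower number from compound 2 to compound 4 (0.00 log units; within the scatter), with no step beyond the scatter expected, though with wide uncertainty. For compound 4 the estimated value is 28 mL/min/kg, with an expected range of 14 mL/min/kg to 55 mL/min/kg.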

Compound 4, clearance: 50.8 mL/min/kg
For compound 4 the middle estimate is 1.8-fold (0.26 log units) below the measured one; the measured number falls inside the stated range.
By their numbers in this assay, from the lowest: compounds 1, 3, 2 and 4 (each within the scatter of the next, the first and the last beyond it).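

In this assay, the aromatic carbon ortho to a chloro group takes 4-(trifluoromethoxy)phenyl in place of methyl, with a 1.8-fold higher number from compound 2 to compound 4 (0.25 log units; within the scatter). This is the first step shown that adds a ring, and even this much larger group leaves the reading inside the scatter. Nothing measured on these compounds offers an explanation for this reading.

Open is how the ring and its trifluoromethoxy group each count, since an unsubstituted phenyl is not among the compounds shown. Also open, on these data alone, is how an amine or a longer chain would read at this position.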